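A few compounds are considered here, and "the series" means these few. Any claim that something is new, unique, unknown or untested is made for them only; others in the source may bear on it.

Compound 1 `CCCc1nc(C)c2c(C(C)C)nnc(S)n12`: > 48000 nM
Compound 2 `CCCc1nc(C)c2ccnc(Nc3cc[nH]n3)n12`: 25000 nM

Among the measured compounds shown here, in a functional assay for inhibition, with Homo sapiens as the target (on this read-out higher numbers stand for weaker inhibition and lower numbers for stronger inhibition), compound 2 gives 25000 nM, the only plain number among the values shown. Compound 1 sits at a limit of this assay, (the limit of > 48000 nM in this assay, at which 1 of the 2 values shown sits). Compound 3 `CCCc1cnc(Nc2cc[nH]n2)n2c(CCC)nc(C)c12` has not been measured. It differs from compound 2 by propyl in place of hydrogen on an aromatic carbon. For the measured compounds named here, no measured pair shows what this change does here, so the step expected is a 1.3-fold lower number from compound 2 to compound 3 (0.10 log units; within the scatter), none beyond the usual scatter. Compound 3 is estimated at 20000 nM, between 5000 nM and 60000 nM.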

Compound 3, half-maximal inhibitory concentration: > 48000 nM
Compound 3 ended at the assay's limit; the forecaster's own chance of this, stated with the estimate: 30%; at least 2.4-fold (0.38 log units) between middle value and limit.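

Among the compounds shown here, putting propyl in place of hydrogen on the aromatic carbon para to a (1H-pyrazol-3-yl)amino group gives the first reading for this position: in this assay the change brings an at least 1.9-fold higher number from compound 2 to compound 3 (0.28 log units; that floor lies within the scatter). This shows no gain from propyl over hydrogen here, but it does not prove a real loss, and the full size of the rise cannot be read. Compound 3 now sits at a limit of the assay, as compound 1 does: the limit of > 48000 nM in this assay, at which 2 of the 3 values shown sit.

As far as these compounds go, whether an amine, a carboxylic acid or a fluorine atom at this position would give a lower number than hydrogen stays open. So does whether a chain shorter than propyl would keep the number of compound 2.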